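Propoxy in Place of Isobutylsulfanyl: Cytotoxicity Outlook

This account rests on a few compounds, and the source may have more. Where it says the series, first, only, none or still open, it means among the compounds named here.

Measured compounds:
compound 1: `CCCCCCCCOc1nc(N)nc2c1ncn2/C=C1/CC1(CO)CO` — > 20000 nM
compound 2: `CCCCSc1nc(N)nc2c1ncn2/C=C1/CC1(CO)CO` — > 20000 nM
compound 3: `CC(C)CSc1nc(N)nc2c1ncn2/C=C1/CC1(CO)CO` — "not determined" (no result reported)

Three compounds share one core and differ only in the group on an aromatic carbon. In an ADME assay on MOLT-3 cells (Homo sapiens) for cytotoxicity, with a stated time of 7 days (on this read-out higher numbers stand for lower toxicity in this test and lower numbers for higher toxicity in this test), compound 1 gives > 20000 nM, which is a limit of the test and not a number. In this assay compound 2 likewise gives > 20000 nM, again a limit. The step that the two limits leave unreadable from compound 1 to compound 2 therefore cannot be read in size, since (the limit of > 20000 nM in this assay, at which 2 of the 3 values shown sit). Compound 3 stands with no value at all in this assay, so its place is known only from the two neighbours, which both sit at the limit.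

Compound 4 is `CCCOc1nc(N)nc2c1ncn2/C=C1/CC1(CO)CO`. Its change from compound 3 is propoxy in place of isobutylsulfanyl on an aromatic carbon. Among the compounds with values here, no measured step bears directly on this change, and the only step available, from octyloxy to butylsulfanyl, is unreadable. The two readable facts are that both measured compounds sit at the limit of this assay. Compound 4 is therefore expected to sit at the same limit, with no step beyond the scatter foreseeable. Compound 4 is estimated at 30000 nM in this assay, within 12000 nM to 100000 nM.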

Compound 4, half-maximal cytotoxic concentration: > 20000 nM
Compound 4 ended at the assay's limit; the forecaster's own chance of this, stated with the estimate: 85%; the middle value does not contradict the limit.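

In this assay compound 4 gives > 20000 nM, which is a limit and not a number. No new step can be read among compound 1, compound 2 and compound 4, because all three values are limits: the limit of > 20000 nM in this assay, at which 3 of the 4 values shown sit.

The compounds shown leave open how far beyond that limit each one lies, and whether any group at this place gives a readable value.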